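Halogen swap on the benzylsulfanyl arm of compound 2

A few compounds are considered here, and "the series" means these few. Any claim that something is new, unique, unknown or untested is made for them only; others in the source may bear on it.

For the measured compounds named here, compound 2 `COc1ccc(C2N=C(SCc3ccc(Cl)cc3)NC(C)=C2C(=O)Nc2ccc(F)cc2)cc1OC` stands highest of the two numbers so far: in a functional assay on the whole organism (artery, strain albino) with Rattus norvegicus as the target, with a stated time of 300 min, at a dose of 10 mg/kg by the oral route (a higher number here means more inhibition at the dose given (going by the name of the read-out), a lower number less inhibition), compound 2 gives 31.3%. Compound 1 `COc1ccc(C2N=C(SCc3cccc(Cl)c3)NC(C)=C2C(=O)Nc2ccc(F)cc2)cc1OC` is its nearest neighbour and in this assay compound 1 gives 16.4%, the two being separated by the step of a number 14.9 percentage points higher from compound 1 to compound 2 (beyond the scatter). Compound 3 `COc1ccc(C2N=C(SCc3ccc(F)cc3)NC(C)=C2C(=O)Nc2ccc(F)cc2)cc1OC` is the next member, derived from compound 2 by the change (fluoro in place of chloro on an aromatic carbon), which read one bond further out is 4-chlorobenzyl to 4-fluorobenzyl. Going by the values given here, no measured step exchanges one halogen for another here; the only step known, a number 14.9 percentage points higher from compound 1 to compound 2 (beyond the scatter), moves the chloro group between ring positions and therefore bears on it only indirectly. With the ring position held, no step beyond the scatter is expected for compound 3, at most a small loss, so the estimated step is a number 4.3 percentage points lower from compound 2 to compound 3 (within the scatter). Compound 3 is thus expected to give 27% in this assay, within 12% to 42%.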

Compound 3, a percentage reported as inhibition, in the whole organism at one dose (the size of the read-out at that dose, not a potency): 37.9%
Beside the measured number, compound 3's estimate is 10.9 percentage points below it; low and high end bracket the measured number.
By their numbers in this assay, from the lowest: compound 1; then compounds 2 and 3 (each within the scatter of the next).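

In this assay, for the compounds shown here, the exchange of 4-chlorobenzyl for 4-fluorobenzyl gives the first direct halogen comparison on this arm, and the result is a number 6.6 percentage points higher from compound 2 to compound 3 (within the scatter); at this ring position, chloro and fluoro cannot be told apart in this read-out. The other new step, a number 21.5 percentage points higher from compound 1 to compound 3 (beyond the scatter), matches the earlier a number 14.9 percentage points higher from compound 1 to compound 2 (beyond the scatter) in direction, so both 4-halobenzyl members stand clear of the 3-chlorobenzyl member, and none of the three compounds goes against this. The link therefore now looks tied to where the halogen sits on the ring rather than to which of these two halogens is present.

Nothing available explains the result. From the compounds shown here alone, whether a halogen is needed here at all remains open, and an unsubstituted benzyl, 4-methoxybenzyl or 4-aminobenzyl group on the same sulfur would test that.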